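Swapping a small amine for a ring on compound 1

The compounds below may be only part of what the source reports. "The series", "measured", "known", "first", "only" and "open" are said of these compounds alone.

Of the compounds shown here, three sharing a core have been measured in an assay on HeLa cells for binding affinity to Vasopressin V2 receptor (Homo sapiens); a lower number here means a stronger inhibitor, a higher number a weaker inhibitor. Compound 1 `CNc1ccc(C(=O)N2CCCCc3ccccc32)c(Cl)c1` gives 35 nM. Compound 2 `O=C(c1ccc(-n2cccc2)cc1)N1CCCCc2ccccc21` gives 320 nM, and compound 3 `O=C(c1ccc(N2CCCC2)cc1Cl)N1CCCCc2cc(Cl)ccc21` gives 16 nM. Compound 1 therefore has the second highest number of the three: compound 3 is its nearest neighbour with a lower number, beyond the scatter, and compound 2 is furthest with a higher number, also beyond the scatter. Compound 4 `O=C(c1ccc(N2CCCCC2)cc1Cl)N1CCCCc2ccccc21` differs from compound 1 in one place: piperidin-1-yl in place of methylamino on an aromatic carbon. Going by the values given here, no directly comparable step has been measured, but the lower number of compound 3 at 16 nM shows that this core can do better than compound 1. A small improvement, or none beyond the scatter, is expected, estimated as a 1.8-fold lower number from compound 1 to compound 4 (0.24 log units; within the scatter). Compound 4 is expected to give 20 nM, within a range from 7 nM to 60 nM.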

Compound 4, half-maximal inhibitory concentration: 120 nM
The estimate for compound 4 lay 6.0-fold (0.78 log units) below the measured number; the measured number lies above the stated range.
By their numbers in this assay, from the lowest: compound 3; then compound 1; then compound 4; then compound 2.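

In this assay, piperidin-1-yl in place of methylamino on this aromatic carbon gives a 3.4-fold higher number from compound 1 to compound 4 (0.54 log units; beyond the scatter), so at this position of the core of compound 1, a larger ring is not a neutral swap. The change adds heavy atoms and a ring, and it also removes the hydrogen-bond donor, and this one step cannot tell these apart. No measurement shown here explains the result.

On these data alone, it remains open whether the loss follows the added ring or the lost donor. A dimethylamino group, which also has no such donor but has no ring, would help separate the two.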